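This account rests on a few compounds, and the source may have more. Where it says the series, first, only, none or still open, it means among the compounds named here.

Measured compounds:
Compound 1 `CCCNC(=O)CC1CCc2cc(OC)c(OC)cc21` – 22.2%
Compound 2 `COc1cc2c(cc1OC)C(CC(=O)NC1CCCC1)CC2` – 40.7%
Compound 3 `COc1cc2c(cc1OC)C(CC(=O)NC1CCCCC1)CC2` – 48.2%

In a functional assay on the whole organism (strain Wistar) for inhibition, with Rattus norvegicus as the target, read by paw edema, with stated times of 60 min and 6 h, at a dose of 100 mg/kg by the oral route (on this read-out higher numbers stand for more inhibition at the one dose given (going by the name of the read-out) and lower numbers for less inhibition), compound 3 gives the highest of the three numbers. Its gap to compound 1 is beyond the scatter, but compound 2 sits within the scatter of compound 3, so the two cannot be ranked against each other.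

Compound 4 `COc1cc2c(cc1OC)C(CC(=O)NCCO)CC2` differs from compound 3 in one place: 2-hydroxyethyl in place of cyclohexyl on an amide-type nitrogen. The change removes the ring and puts a short chain on the amide-type nitrogen.

Within the data shown here, two measured steps bear on this. Replacing the propyl chain by a ring raised inhibition: a number 18.5 percentage points higher from compound 1 to compound 2 (beyond the scatter) and a number 26 percentage points higher from compound 1 to compound 3 (beyond the scatter). Going from one ring to a larger ring changed little: a number 7.5 percentage points higher from compound 2 to compound 3 (within the scatter). So, in the numbers shown, a chain on the amide-type nitrogen gave less inhibition than a ring, though only one chain has been measured, and no chain carrying an oxygen has been measured at all.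

Compound 4 is therefore expected to fall back toward the level of compound 1, the expected step being a number 23.2 percentage points lower from compound 3 to compound 4 (beyond the scatter), and the estimate for compound 4 is 25%, with a range from 10% to 40%.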

Compound 4, a percentage reported as inhibition, in the whole organism at one dose (the size of the read-out at that dose, not a potency): 13%
Compound 4: middle estimate off by 12 percentage points, on the high side, within the range that was stated.
By their numbers in this assay, from the lowest: compounds 4 and 1 (each within the scatter of the next); then compounds 2 and 3 (each within the scatter of the next).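

In this assay, losing the ring in favour of 2-hydroxyethyl is costly from either ring size, with a number 35.2 percentage points lower from compound 3 to compound 4 (beyond the scatter) and a number 27.7 percentage points lower from compound 2 to compound 4 (beyond the scatter) both printed as beyond the scatter. The chain's hydroxy group, the first oxygen on this amide-type nitrogen substituent, does not separate it from the plain propyl chain, since a number 9.2 percentage points lower from compound 1 to compound 4 (within the scatter) lies within the scatter. Among these compounds, at this position, the two chain compounds therefore form one group and the two ring compounds another, and none of the four compounds goes against this split, although it rests on only two chains and two rings.

No measurement here explains these differences. As far as these compounds go, it remains open whether a hydroxycyclohexyl group, which keeps the ring and adds the oxygen, would stay with the ring compounds or fall to the chain compounds, and how a longer chain such as hexyl or a chain ending in an amine would behave.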